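This account rests on a few compounds, and the source may have more. Where it says the series, first, only, none or still open, it means among the compounds named here.

Measured so far:
compound 1 `Cn1cc(-c2cnc(NCc3c(F)ccc4c3CCO4)c3cn[nH]c(=O)c23)cn1` at 21 mL.min-1.g-1
compound 2 `CC1(C)CC(=O)N(c2cnc(NCc3c(F)ccc4c3CCO4)n3cnnc23)C1` at 16 mL.min-1.g-1

In an ADME assay on microsomes from liver (Homo sapiens) for metabolic stability, read by LC-MS, using NADPH, with stated times of 5 min and 30 min, tested at 1 uM (a higher number here means faster removal of the compound, a lower number slower removal), compound 2 at 16 mL.min-1.g-1 lies within the scatter of compound 1 at 21 mL.min-1.g-1 and the two cannot be told apart. Compound 3 `O=C1CC2(CC2)CN1c1cnc(NCc2c(F)ccc3c2CCO3)n2cnnc12` replaces the 4,4-dimethyl-2-oxopyrrolidin-1-yl group of compound 2, on an aromatic carbon: a group of 8 heavy atoms (6 carbon, 1 nitrogen, 1 oxygen; one three-membered non-aromatic ring of carbon only, one five-membered non-aromatic ring with 1 hetero atom) in place of a group of 8 heavy atoms (6 carbon, 1 nitrogen, 1 oxygen; one five-membered non-aromatic ring with 1 hetero atom), on an aromatic carbon. Within the data shown here, no measured pair shows this change, so no step beyond the scatter is expected, in either direction. The estimated size is a 1.1-fold lower number from compound 2 to compound 3 (0.03 log units; within the scatter) and stays within the scatter. For compound 3 the estimate is 15 mL.min-1.g-1 with an expected range from 8 mL.min-1.g-1 to 28 mL.min-1.g-1.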

Compound 3, intrinsic clearance in microsomes: < 3 mL.min-1.g-1
Compound 3: a limit, no number (the forecaster's own chance of this, stated with the estimate: 5%); at least 5.0-fold (0.69 log units) between middle value and limit.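

In this assay, the aromatic carbon para to a large group responds to a small edit: with the count of 8 heavy atoms unchanged, the three-membered carbon ring in place of the 4,4-dimethyl-2-oxopyrrolidin-1-yl group's two methyls gives an at least 5.3-fold lower number from compound 2 to compound 3 (0.72 log units; beyond the scatter). The earlier compounds shown here offered no step at this position. For compound 3 the reading is a limit of the assay, not a number: the limit of < 3 mL.min-1.g-1 in this assay, at which 1 of the 3 values shown sits.

One pair leaves the true size of this step open and does not show whether it holds on other cores. As far as these compounds go, how an amine or a longer chain on this carbon would read also remains open.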